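Silyl Thiourea Analogues at the Limit of Agonist Detection

This account rests on a few compounds, and the source may have more. Where it says the series, first, only, none or still open, it means among the compounds named here.

Compound 1 `C[Si](C)(C)c1ccc(CNC(=S)NCc2ccc(NS(C)(=O)=O)cc2)cc1` gives > 100000 nM in a functional assay on cells (strain Sprague-Dawley) for agonist activity at transient receptor potential cation channel subfamily V member 1 (Rattus norvegicus), read by scintillation counting (a lower number here means that less compound is needed, a higher number that more compound is needed for the effect), a limit of the assay.
Compound 2 `CC[Si](CC)(CC)c1ccc(CNC(=S)NCc2ccc(NS(C)(=O)=O)cc2)cc1` gives > 100000 nM in this assay, again a limit.
Compound 3 `C[C@@H](NC(=S)NCc1ccc([Si](C)(C)C)cc1)c1ccc(NS(C)(=O)=O)cc1` gives > 100000 nM in this assay, also a limit.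

Compound 3 therefore stands where every value shown stands: at the limit of > 100000 nM in this assay, at which 3 of the 3 values shown sit, so it cannot be placed above or below the other two compounds. Compound 4 `CC[Si](CC)(CC)c1ccc(CNC(=S)N[C@H](C)c2ccc(NS(C)(=O)=O)cc2)cc1` differs from compound 3 by a group of 7 heavy atoms (6 carbon, 1 silicon; no ring) in place of a group of 4 heavy atoms (3 carbon, 1 silicon; no ring), on an aromatic carbon. The same change has been made once before, in the step from compound 1 to compound 2, where a step that the two limits leave unreadable from compound 1 to compound 2; the step from compound 1 to compound 3, a step that the two limits leave unreadable from compound 1 to compound 3, is equally unreadable because the limit of > 100000 nM in this assay, at which 3 of the 3 values shown sit, caps both ends. Going by the values given here, no measured step gives a readable size, so no direction beyond the scatter can be expected for a step that the limit leaves unreadable from compound 3 to compound 4, and the most likely outcome is another limit. Compound 4 is estimated at 150000 nM, with a range from 30000 nM to 1000000 nM.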

Compound 4, half-maximal effective concentration: > 100000 nM
Compound 4 ended at the assay's limit; the forecaster's own chance of this, stated with the estimate: 85%; the middle value lies beyond the limit too.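

Compound 4 sits at the same limit as compound 2 and compound 3 in this assay, so neither new step, to compound 4 from compound 3 or from compound 2, can be read: the limit of > 100000 nM in this assay, at which 4 of the 4 values shown sit.

The compounds shown leave open whether either change, the larger silicon-bearing group or the added methyl, has any effect in this assay.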